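The source may hold more compounds than are shown below. What is called first, only, known or untested is meant among the compounds shown, and "the series" means these compounds.

Compound 1, `Cc1ccccc1C(=O)NC(CCN(C)C)c1ccc(Cl)cc1`: 175% in an assay on NIH3T3 cells with Urotensin-2 receptor (Homo sapiens) as the target; on this read-out lower numbers stand for smaller maximal responses and higher numbers for larger maximal responses.
Compound 2, `COc1cccc(C(=O)NC(CCN(C)C)c2ccc(Cl)cc2)c1C`: 179% in this assay.

Compound 2 holds the higher of the two numbers, yet the step of a number 4 percentage points higher from compound 1 to compound 2 (within the scatter) leaves the two indistinguishable within the scatter. Compound 3, `Cc1c(Cl)cccc1C(=O)NC(CCN(C)C)c1ccc(Cl)cc1`, differs from compound 2 in one place: chloro in place of methoxy on an aromatic carbon. Within the data shown here, the only measured step that bears on this position is a number 4 percentage points higher from compound 1 to compound 2 (within the scatter), which put methoxy in place of hydrogen on an aromatic carbon and stayed within the scatter. Among the measured compounds shown here, no measured pair sets chloro against methoxy, so the direction of the present change cannot be read from these two compounds. On this basis a step no larger than the scatter is expected in this assay, a number 4 percentage points lower from compound 2 to compound 3 (within the scatter). Compound 3 is therefore estimated at 175%, with a range from 150% to 200%.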

Compound 3, largest response reached (reported as efficacy), in percent of the reference or control that the assay uses: 142%
Estimate against measurement, compound 3: 33 percentage points above; measured number outside the range, below it.
By their numbers in this assay, from the lowest: compound 3; then compounds 1 and 2 (each within the scatter of the next).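

The position ortho to a methyl group and meta to a large group is not indifferent to what it carries, as the earlier pair alone might have suggested. In this assay, chloro gives a clear drop against hydrogen (a number 33 percentage points lower from compound 1 to compound 3 (beyond the scatter)) and against methoxy (a number 37 percentage points lower from compound 2 to compound 3 (beyond the scatter)), whereas methoxy had stayed within the scatter of hydrogen. Nothing available accounts for this difference between chloro and methoxy.

With only hydrogen, methoxy and chloro seen on this carbon, the compounds shown leave open whether fluoro, bromo, hydroxy or an amine would follow chloro or methoxy. They also leave open whether the drop with chloro would persist if the neighbouring methyl group gave way to hydrogen or ethyl.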